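The compounds below may be only part of what the source reports. "The series", "measured", "known", "first", "only" and "open" are said of these compounds alone.

Of the compounds shown here, two have been measured so far. Compound 1 `O=S(=O)(NCCNCc1cccc2ccccc12)c1cc(C(F)(F)F)cc(C(F)(F)F)c1` gives 21000 nM in a functional assay on Capan-2 cells (Homo sapiens) for inhibition, read by MTT assay, with a stated time of 72 h (a lower number here means a stronger inhibitor of growth, a higher number a weaker inhibitor of growth), and compound 2 `O=S(=O)(NCCCNCc1ccccc1Cl)c1cc(C(F)(F)F)cc(C(F)(F)F)c1` gives 13000 nM in the same assay. The gap between these two numbers lies within the usual scatter of repeated measurements, so neither compound can be called the stronger or weaker inhibitor of growth on this evidence.

The next compound, compound 3 `CC(C)(C)c1ccc(CNCCCNS(=O)(=O)c2cc(C(F)(F)F)cc(C(F)(F)F)c2)cc1`, differs from compound 2 in one place: 4-(tert-butyl)phenyl in place of 2-chlorophenyl on a saturated chain carbon bound to an amine nitrogen. Among the compounds with values here, no measured pair in this set shows the effect of such a change, so there is no step to lean on. Both measured compounds sit in the same broad range, and the change does not touch the shared core, the chain or the sulfonamide. The step from compound 2 to compound 3 in this assay is therefore expected to be small, a 1.3-fold lower number from compound 2 to compound 3 (0.11 log units; within the scatter), in no clear direction beyond the scatter. Compound 3 is estimated at 10000 nM, with a range from 3000 nM to 35000 nM.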

Compound 3, concentration for 50% growth inhibition: 2100 nM
Estimate against measurement, compound 3: 4.8-fold (0.68 log units) above, and the stated range ends above it.
By their numbers in this assay, from the lowest: compound 3; then compounds 2 and 1 (each within the scatter of the next).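

In this assay, putting 4-(tert-butyl)phenyl in place of 2-chlorophenyl on a saturated chain carbon bound to an amine nitrogen gives a 6.2-fold lower number from compound 2 to compound 3 (0.79 log units; beyond the scatter), a step beyond the scatter. Within the data shown here, this is the first clear sign that the group at this position can change growth inhibition, which the two earlier compounds could not show, as they differ from each other in more than one place and their values lie within the scatter. Nothing measured here explains the step.

On these data alone, the swap removes the chlorine and brings in the tert-butyl group in a single move, so the share of each remains unknown. As far as these compounds go, a plain phenyl, 4-chlorophenyl or 2-(tert-butyl)phenyl at the same position would help separate the two, and whether the step holds on a two-carbon chain also remains open.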